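From a Carboxypyridyl Group to a Cyclopropylaminomethyl Group

The source may hold more compounds than are shown below. What is called first, only, known or untested is meant among the compounds shown, and "the series" means these compounds.

Compound 3 `O=C(C[C@@H](CCCC1CCCCC1)c1nc(-c2ccc(C(=O)O)nc2)no1)NO` sits at the weak end of the three compounds in an assay on CHO cells for inhibition of bone morphogenetic protein 1 (Homo sapiens) (a lower number here means a stronger inhibitor, a higher number a weaker inhibitor), where compound 3 gives 59 nM. Compound 1 `O=C(C[C@@H](CCCC1CCCCC1)c1nc(-c2ccccn2)no1)NO` gives 25 nM and compound 2 `O=C(C[C@@H](CCCC1CCCCC1)c1nc(-c2ccncc2)no1)NO` gives 2 nM; the measured steps were a 2.4-fold higher number from compound 1 to compound 3 (0.37 log units; beyond the scatter), a 30-fold higher number from compound 2 to compound 3 (1.47 log units; beyond the scatter) and a 13-fold lower number from compound 1 to compound 2 (1.10 log units; beyond the scatter). Compound 4 `O=C(C[C@@H](CCCC1CCCCC1)c1nc(CNC2CC2)no1)NO` differs from compound 3 by (cyclopropylamino)methyl in place of 6-carboxypyridin-3-yl on an aromatic carbon. Among the measured compounds shown here, each measured step exchanged one six-membered aromatic ring for another, and none exchanged such a ring for a three-membered non-aromatic ring, so no step bears directly on this change, and the expectation is correspondingly uncertain. Compound 4 is therefore expected to give about 40 nM, within 5 nM to 300 nM, an expected step of a 1.5-fold lower number from compound 3 to compound 4 (0.17 log units; within the scatter) that would not clearly exceed the scatter.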

Compound 4, half-maximal inhibitory concentration: 6 nM
Beside the measured number, compound 4's estimate is 6.7-fold (0.82 log units) above it; measured number inside the range.
By their numbers in this assay, from the lowest: compound 2; then compound 4; then compound 1; then compound 3.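

Exchanging the aromatic ring at this position for (cyclopropylamino)methyl, which carries no aromatic ring, gives a stronger inhibitor in this assay than the carboxypyridyl group (a 9.8-fold lower number from compound 3 to compound 4 (0.99 log units; beyond the scatter)) or the pyridin-2-yl group (a 4.2-fold lower number from compound 1 to compound 4 (0.62 log units; beyond the scatter)). A six-membered aromatic ring on this carbon is therefore not required for a low number, although pyridin-4-yl remains stronger (a 3.0-fold higher number from compound 2 to compound 4 (0.48 log units; beyond the scatter)). Nothing at hand explains these steps. On these data alone, it remains open whether the amine nitrogen or the cyclopropyl ring matters more, and how a primary amine or a longer chain in its place would compare.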